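This account rests on a few compounds, and the source may have more. Where it says the series, first, only, none or still open, it means among the compounds named here.

Measured in an in vitro assay on Sf9 cells for inhibition of RAC-alpha serine/threonine-protein kinase (Homo sapiens), read by AlphaScreen, with a stated time of 20 min; on this read-out lower numbers stand for stronger inhibition and higher numbers for weaker inhibition:
Compound 1 `Nc1ccc(-n2c(-c3cccnc3N)nc3cccnc32)cc1` gives 740 nM.
Compound 2 `Nc1ncccc1-c1nc2cccnc2n1-c1ccc(CNC(=O)C2CCCCC2)cc1` gives 250 nM.
Compound 3 `CC(C)(C)c1ccc(-n2c(-c3cccnc3N)nc3cccnc32)cc1` gives 3900 nM.

Compound 3 stands highest of the three in this assay, with a 5.3-fold higher number from compound 1 to compound 3 (0.72 log units; beyond the scatter) and a 16-fold higher number from compound 2 to compound 3 (1.19 log units; beyond the scatter). Compound 4 `CC(=O)NCc1ccc(-n2c(-c3cccnc3N)nc3cccnc32)cc1` carries acetamidomethyl in place of tert-butyl on an aromatic carbon. The step bearing most directly on this change is a 16-fold higher number from compound 2 to compound 3 (1.19 log units; beyond the scatter), which ties a group of the same kind to a large shift; a 5.3-fold higher number from compound 1 to compound 3 (0.72 log units; beyond the scatter) points the same way. Compound 4 is expected to fall between compound 1 and compound 2, because compound 2 gives 250 nM with a group that likewise holds one donor and one acceptor. A large drop is therefore expected: a 7.8-fold lower number from compound 3 to compound 4 (0.89 log units; beyond the scatter). Compound 4 is estimated at 500 nM, within a range from 150 nM to 1500 nM.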

Compound 4, half-maximal inhibitory concentration: 810 nM
Compound 4: the middle estimate sits 1.6-fold (0.21 log units) below what was measured; the measured number falls inside the stated range.
By their numbers in this assay, from the lowest: compound 2; then compounds 1 and 4 (each within the scatter of the next); then compound 3.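

Swapping tert-butyl for acetamidomethyl on this aromatic carbon gives a 4.8-fold lower number from compound 3 to compound 4 (0.68 log units; beyond the scatter), so an amide-bearing group here again outperforms tert-butyl, now with a small acyl end. The size of that end matters, as methyl in place of cyclohexyl on the carbonyl carbon gives a 3.2-fold higher number from compound 2 to compound 4 (0.51 log units; beyond the scatter), whereas acetamidomethyl in place of amino gives a 1.1-fold higher number from compound 1 to compound 4 (0.04 log units; within the scatter) and the two cannot be told apart. No supporting measurement explains these shifts.

From the compounds shown here alone, what propyl or phenyl on the carbonyl carbon would give remains open. So does the outcome for a sulfonamide or a carboxylic acid at this position.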